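Tertiary Thiourea Variant Tested for Cytotoxicity

The source may report more compounds than this note shows. Statements on the series, on what has been measured and on what is new or still open speak of the compounds shown alone.

The series shares the core of compound 1 `Fc1cccc(F)c1NC(=S)N/N=C\c1c[nH]c2ccccc12`, a thiosemicarbazone bearing a 2,6-difluorophenyl group on the amide-type nitrogen. In an ADME assay on KB cells (Homo sapiens) for cytotoxicity, read by MTT assay, with a stated time of 44 h (a lower number here means a stronger inhibitor, a higher number a weaker inhibitor), compound 1 gives > 100000 nM, which is a limit of the assay rather than a number. Compound 2 `CC(C)NC(=S)N/N=C\c1c[nH]c2ccccc12` carries an isopropylamino group on the thiocarbonyl carbon. In this assay compound 2 gives > 100000 nM, again a limit and not a number. Compound 3 `Cc1ccccc1NC(=S)N/N=C\c1c[nH]c2ccccc12` in this assay gives > 100000 nM, likewise a limit. The step that the two limits leave unreadable from compound 2 to compound 3 therefore cannot be read in size, since both ends sit at the limit of > 100000 nM in this assay, at which 3 of the 3 values shown sit. Compound 2 thus stands at the assay limit, with every other value shown at the same limit, and no order among the three compounds can be stated.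

Compound 4 `CCCCN(C)C(=S)N/N=C\c1c[nH]c2ccccc12` differs from compound 2 by butyl(methyl)amino in place of isopropylamino on a thiocarbonyl carbon. For the measured compounds named here, the only measured step that touches this position is a step that the two limits leave unreadable from compound 2 to compound 3, and it is unreadable, so no direction or size can be drawn from it. With all shown values at the limit of > 100000 nM in this assay, at which 3 of the 3 values shown sit, compound 4 is expected to remain at or near that limit, with no step beyond the scatter discernible. The step this estimate means is expected to be a step that the limit leaves unreadable from compound 2 to compound 4. Compound 4 is estimated at 150000 nM, ranging from 50000 nM to 400000 nM.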

Compound 4, half-maximal inhibitory concentration: > 100000 nM
Compound 4: only a limit was reported; the forecaster's own chance of this, stated with the estimate: 85%; the middle value lies beyond the limit too.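

In this assay compound 4 gives > 100000 nM, which is a limit of the assay. No step can therefore be read between compound 2 and compound 4, and the result sits with the others: the limit of > 100000 nM in this assay, at which 4 of the 4 values shown sit.

The compounds shown leave open whether any group on the thiocarbonyl carbon changes the read-out in this assay at all.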